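Ring swap on the charged chain end: two cores compared

The source may hold more compounds than are shown below. What is called first, only, known or untested is meant among the compounds shown, and "the series" means these compounds.

Measured so far, in an assay on LX2 cells for inhibition of COL1A1 promoter (Homo sapiens), read by a luciferase reporter, with a stated time of 24 h, tested at 20 uM; a lower number here means a weaker effect, a higher number a stronger effect of the compound at the concentration tested: compound 1 `Cc1cc(-n2cc(C(=O)Nc3cc(F)cc(F)c3)c(=O)c3ccc(N(C)C)nc32)ccc1OCCCCCCC[N+]1(C)CCN(C)CC1` gives 16.2%; compound 2 `Cc1cc(OCCCCCCC[N+]2(C)CCN(C)CC2)cc(-n2cc(C(=O)Nc3cc(F)cc(F)c3)c(=O)c3ccc(N(C)C)nc32)c1` gives 2.8%; compound 3 `CC[N+]1(CCCCCCCOc2ccc(-n3cc(C(=O)Nc4cc(F)cc(F)c4)c(=O)c4ccc(N(C)C)nc43)cc2C)CCCC1` gives 44.7%.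

Compound 1 and compound 2 are built from the same atoms joined differently; the difference between the two cores is not broken down here. Compound 1 and compound 3 share a core and differ only at the chain end: a group of 7 heavy atoms (6 carbon, 1 nitrogen; one five-membered non-aromatic ring with 1 hetero atom) in place of a group of 8 heavy atoms (6 carbon, 2 nitrogen; one six-membered non-aromatic ring with 2 hetero atoms), on a saturated chain carbon, seven bonds along the chain from an oxygen on an aromatic ring. That change gave a step of a number 28.5 percentage points higher from compound 1 to compound 3 (beyond the scatter) in this assay. Compound 4 `CC[N+]1(CCCCCCCOc2cc(C)cc(-n3cc(C(=O)Nc4cc(F)cc(F)c4)c(=O)c4ccc(N(C)C)nc43)c2)CCCC1` carries the same kind of change on the core of compound 2: a group of 7 heavy atoms (6 carbon, 1 nitrogen; one five-membered non-aromatic ring with 1 hetero atom) in place of a group of 8 heavy atoms (6 carbon, 2 nitrogen; one six-membered non-aromatic ring with 2 hetero atoms), on a saturated chain carbon, seven bonds along the chain from an oxygen on an aromatic ring. Because compound 1 to compound 3 moved by a number 28.5 percentage points higher from compound 1 to compound 3 (beyond the scatter), a rise is expected for compound 4 as well, though the different core of compound 2 makes the size uncertain. The step from compound 2 to compound 4 is expected to be a number 22.2 percentage points higher from compound 2 to compound 4 (beyond the scatter). Compound 4 is estimated at 25%, between 5% and 50%.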

Compound 4, a percentage reported as inhibition, at one concentration (the size of the read-out at that concentration, not a potency): 35.1%
Estimate against measurement, compound 4: 10.1 percentage points below; the measured number falls inside the stated range.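

The change from the six-membered ring with two hetero atoms to the five-membered ring with one hetero atom at the chain end gave, in this assay, a number 32.3 percentage points higher from compound 2 to compound 4 (beyond the scatter) on the second core. The gain therefore carried over from one core to the other with its size preserved: the same change on two cores in this assay, a number 28.5 percentage points higher (beyond the scatter) from compound 1 to compound 3 and a number 32.3 percentage points higher (beyond the scatter) from compound 2 to compound 4, 3.8 percentage points apart, within the scatter of two such steps. Among the compounds shown here, this rests on only two cores at one concentration, so it shows neither a general rule for the series nor any change in potency, and it does not explain why the change raises the read-out.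

The compounds shown leave open whether a piperidine or morpholine ring at the chain end would behave the same way. They also leave open whether the step would survive on a shorter or longer chain.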